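Chloro for Methoxy on a Chalcone Dithiocarbamate

The source may report more compounds than this note shows. Statements on the series, on what has been measured and on what is new or still open speak of the compounds shown alone.

Measured so far:
- compound 1, `O=C(/C=C/c1ccc(Cl)cc1)c1ccc(OCCCSC(=S)N2CCCC2)cc1`, gives 18600 nM in a functional assay on ECa-109 cells for inhibition, with ECa-109 cell line (Homo sapiens) as the target, read by MTT assay, with a stated time of 72 h; on this read-out higher numbers stand for weaker inhibition and lower numbers for stronger inhibition
- compound 2, `COc1ccc(/C=C/C(=O)c2ccc(OCCCSC(=S)N3CCN(C)CC3)cc2)cc1`, gives > 100000 nM in this assay

Of the compounds shown here, two have been tested in this assay. Compound 1 carries a chloro group on one aromatic ring and a pyrrolidine-bearing dithiocarbamate chain on the other side of the shared core, and it gives 18600 nM. Compound 2 is reported only as a limit in this assay, > 100000 nM, which is where the assay stops counting and not a measured number; on the numbers shown, compound 2 therefore stands at the limit of > 100000 nM in this assay, at which 1 of the 2 values shown sits, with no figure of its own.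

Compound 3, `CN1CCN(C(=S)SCCCOc2ccc(C(=O)/C=C/c3ccc(Cl)cc3)cc2)CC1`, keeps the methylpiperazine dithiocarbamate chain of compound 2 and changes one group: chloro in place of methoxy on an aromatic carbon. Within the data shown here, no measured pair shows this exact change. The two values shown, a real number for the chloro compound 1 and a limit for the methoxy compound 2, point towards a lower number, meaning stronger inhibition, as the more likely direction, though the size cannot be read from them. Compound 3 is estimated at 40000 nM, within 10000 nM to 150000 nM, which means an expected step of an at least 2.5-fold lower number from compound 2 to compound 3 (0.39 log units; beyond the scatter).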

Compound 3, half-maximal inhibitory concentration: 34200 nM
Estimate against measurement, compound 3: 1.2-fold (0.07 log units) above; low and high end bracket the measured number.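

Among these compounds, compound 3 supplies the first comparison of methoxy and chloro on an aromatic carbon para to a large group, with the methylpiperazine dithiocarbamate chain held the same. In this assay, chloro in place of methoxy gives an at least 2.9-fold lower number from compound 2 to compound 3 (0.46 log units; beyond the scatter), so this position does respond to the change. The true size of that step stays unknown because compound 2 is reported only as a limit and not as a number: the limit of > 100000 nM in this assay, at which 1 of the 3 values shown sits.

The new compound also allows the chain to be compared while the chloro group stays in place: 4-methylpiperazin-1-yl in place of pyrrolidin-1-yl on the thiocarbonyl carbon gives a 1.8-fold higher number from compound 1 to compound 3 (0.26 log units; within the scatter), so these two rings cannot be told apart on this read-out.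

The compounds shown leave open whether chloro and methoxy would differ in the same way with the pyrrolidine chain, and how a fluoro group or a nitrile would compare at the same aromatic carbon. They also leave open what a longer chain linking the dithiocarbamate to the shared core would do.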